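The compounds below may be only part of what the source reports. "The series", "measured", "known", "first", "only" and "open" are said of these compounds alone.

Measured compounds:
compound 1 `CCOC(=O)c1sc2ccc(NCc3nc[nH]c3C)cc2c1NC(=O)c1ccc(OC)cc1` — 8220 nM
compound 2 `CCOC(=O)c1sc2ccc(NCc3nc[nH]c3C)cc2c1NC(=O)c1ccc(C(F)(F)F)cc1` — 12800 nM

Going by the values given here, in a functional assay on HeLa cells (Homo sapiens) for antiproliferative activity, read by MTT assay, with a stated time of 48 h (a lower number here means a stronger inhibitor of growth, a higher number a weaker inhibitor of growth), compound 2 gives the higher of the two numbers, though its only neighbour is compound 1 and the step of a 1.6-fold higher number from compound 1 to compound 2 (0.19 log units; within the scatter) lies within the scatter. Compound 3 `CCOC(=O)c1sc2ccc(NCc3nc[nH]c3C)cc2c1NC(=O)c1ccc(F)c(Cl)c1` differs from compound 2 by 3-chloro-4-fluorophenyl in place of 4-(trifluoromethyl)phenyl on a carbonyl carbon. Among the compounds with values here, the one measured step that bears on exchanging the aryl group is that from compound 1 to compound 2, and it stayed within the scatter, so compound 3 is expected to show a step of a 1.3-fold lower number from compound 2 to compound 3 (0.11 log units; within the scatter) of no real size. Compound 3 is therefore estimated at 10000 nM, with a range of 4000 nM to 28000 nM.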

Compound 3, concentration for 50% growth inhibition: 2910 nM
Compound 3: middle estimate off by 3.4-fold (0.54 log units), on the high side, outside the stated range (below it).
By their numbers in this assay, from the lowest: compound 3; then compounds 1 and 2 (each within the scatter of the next).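

In this assay the aryl group on the carbonyl carbon turned out able to move the number beyond the scatter, which the earlier pair had not shown: 3-chloro-4-fluorophenyl gave a 4.4-fold lower number from compound 2 to compound 3 (0.64 log units; beyond the scatter) in place of 4-(trifluoromethyl)phenyl and a 2.8-fold lower number from compound 1 to compound 3 (0.45 log units; beyond the scatter) in place of 4-methoxyphenyl. Both steps are modest. Nothing available explains them. The compounds shown leave open whether the chlorine or the fluorine of the 3-chloro-4-fluorophenyl group carries these steps. They also leave open how an amine or a carboxylic acid on that ring would read.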